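A few compounds are considered here, and "the series" means these few. Any claim that something is new, unique, unknown or untested is made for them only; others in the source may bear on it.

Measured so far:
compound 1 `Clc1ccc(-c2cc3ccccc3[nH]2)cc1Cl`: 22.7%
compound 2 `Cn1c(-c2ccc(Cl)c(Cl)c2)cc2ccccc21`: 20%
compound 3 `Cn1c(-c2ccccc2)cc2cc([N+](=O)[O-])ccc21`: 77%

All three numbers come from an assay on isolated protein for inhibition of Aromatase (Homo sapiens), read by fluorescence, using NADPH, with a stated time of 30 min, tested at 50 uM; a lower number here means less inhibition, a higher number more inhibition at the concentration tested (going by the name of the read-out). Compound 3 stands highest of the three, and its distance to compound 1 and to compound 2 is beyond the scatter in both cases. Compound 1 and compound 2 lie within the scatter of each other, so no order is read between them.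

Among the compounds with values here, the one counted step in the set runs from compound 2 to compound 1: hydrogen in place of methyl on an aromatic nitrogen. In this assay this gives a number 2.7 percentage points higher from compound 2 to compound 1 (within the scatter). How the core of compound 2 differs from the core of compound 3 is not broken down here.

The unmeasured compound 4 `O=[N+]([O-])c1ccc2[nH]c(-c3ccccc3)cc2c1` is made from compound 3 by hydrogen in place of methyl on an aromatic nitrogen. This is the same kind of change as the step from compound 2 to compound 1, not the same: in compound 3 the ring atom next to the nitrogen bears a phenyl group (6 heavy atoms), in compound 2 it bears a group of 8 heavy atoms. The starting level is set by compound 3, which gives 77%. Because a number 2.7 percentage points higher from compound 2 to compound 1 (within the scatter) is within the scatter, the expectation for compound 4 is a step of about the same small size, a number 1 percentage points lower from compound 3 to compound 4 (within the scatter). One earlier example carries this expectation and it rests on a different core. Compound 4 is therefore estimated to give about 76% in this assay, expected to fall between 58% and 90%.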

Compound 4, a percentage reported as inhibition, at one concentration (the size of the read-out at that concentration, not a potency): 77.7%
Compound 4: the middle estimate sits 1.7 percentage points below what was measured; low and high end bracket the measured number.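

In this assay, hydrogen in place of methyl on an aromatic nitrogen gives a number 0.7 percentage points higher from compound 3 to compound 4 (within the scatter). Set beside the earlier case, this change carries across the two cores with no difference that can be read between the steps: the same change on two cores in this assay, a number 2.7 percentage points higher (within the scatter) from compound 2 to compound 1 and a number 0.7 percentage points higher (within the scatter) from compound 3 to compound 4, 2 percentage points apart, within the scatter of two such steps. This holds for two pairs only, each read at one concentration, which gives the size of the read-out and not a potency; it does not show that the step stays this small on a further core, and it assigns no role to the methyl or to the hydrogen on that nitrogen.

The compounds shown carry only hydrogen or methyl on the aromatic nitrogen, which leaves open how a longer chain such as propyl or a carbonyl-bearing group such as acetyl would read there. As far as these compounds go, the nitro group of compound 3 and compound 4 is also not separated from the other differences between the cores by any single-place step, so it remains open how the read-out would respond if an amine or a carboxylic acid stood in its place.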